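A few compounds are considered here, and "the series" means these few. Any claim that something is new, unique, unknown or untested is made for them only; others in the source may bear on it.

Among the compounds with values here, in a functional assay (aorta) with Oryctolagus cuniculus as the target (on this read-out lower numbers stand for tighter binding and higher numbers for weaker binding), compound 1 `COc1cc(C(C)=O)ccc1OCCCN1CCC(C(c2ccc(F)c(F)c2)c2ccc(F)c(F)c2)CC1` gives 2.51 nM, and compound 2 `COc1cc(C(C)=O)ccc1OCCCN1CCC(C(O)(c2ccc(F)c(F)c2)c2ccc(F)c(F)c2)CC1` gives 2.51 nM; the one measured step is no change at the digits printed from compound 1 to compound 2 (within the scatter). Compound 3 `N#Cc1ccc(OCCCN2CCC(C(c3ccc(F)cc3)c3ccc(F)cc3)CC2)cc1` gives 5.01 nM, the highest of the three numbers, although its gaps to compound 1 and to compound 2 both lie within the scatter. Compound 4 `Fc1ccc(C(c2ccc(F)cc2)C2CCN(CCCSc3ccccc3)CC2)cc1` has not been measured. It differs from compound 3 in one place: phenylsulfanyl in place of 4-cyanophenoxy on a saturated chain carbon, three bonds along the chain from an amine nitrogen in a ring. Within the data shown here, the only measured step, hydroxy in place of hydrogen, touches a different part of the molecule, so no measured step bears on this change. With nothing to lean on, the expectation for compound 4 is a shift of a 1.3-fold higher number from compound 3 to compound 4 (0.10 log units; within the scatter), nothing clearly beyond the scatter. Compound 4 is therefore estimated at 6.3 nM, within a range from 1.6 nM to 25 nM.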

Compound 4, dissociation constant: 3.16 nM
Compound 4: middle estimate off by 2.0-fold (0.30 log units), on the high side; the measured number falls inside the stated range.
By their numbers in this assay, from the lowest: compounds 1, 2, 4 and 3 (each within the scatter of the next).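

In this assay phenylsulfanyl in place of 4-cyanophenoxy gives a 1.6-fold lower number from compound 3 to compound 4 (0.20 log units; within the scatter) and so stays within the scatter, even though the nitrile leaves and sulfur enters where oxygen stood. Within the data shown here, this is the first measured step on this saturated chain carbon, three bonds along the chain from an amine nitrogen in a ring. Nothing available explains why the change is tolerated here.

The nitrile and the sulfur change together in this step, and a phenoxy group at this place would tell them apart. On these data alone, how an amine or a carboxylic acid on the aromatic ring would read stays open.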